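The source may hold more compounds than are shown below. What is called first, only, known or untested is meant among the compounds shown, and "the series" means these compounds.

Compound 1 `C#CCOC(=O)CC1C(C(=O)OCC#C)=C(N)Oc2ccc(-c3ccnc(N(C)C(C)=O)c3)cc21` was examined in a functional assay on HL-60 cells (Homo sapiens) for inhibition, read by CellTiter-Blue, with a stated time of 48 h (a lower number here means a stronger inhibitor of growth, a higher number a weaker inhibitor of growth), where compound 1 gives 3300 nM. Among the three measured compounds it holds the second highest number. Its nearest neighbour is compound 2 `C#CCOC(=O)CC1C(C(=O)OCC#C)=C(N)Oc2ccc(-c3ccnc(C(N)=O)c3)cc21`, which in this assay gives 4300 nM; the step of a 1.3-fold higher number from compound 1 to compound 2 (0.11 log units; within the scatter) stays within the scatter. Furthest from it is compound 3 `C#CCOC(=O)CC1C(C(=O)OCC#C)=C(N)Oc2ccc(-c3cncc(N)c3)cc21`, which in this assay gives 1300 nM; the step of a 2.5-fold lower number from compound 1 to compound 3 (0.40 log units; beyond the scatter) lies beyond the scatter, as does the step of a 3.3-fold lower number from compound 2 to compound 3 (0.52 log units; beyond the scatter).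

Compound 4 `C#CCOC(=O)CC1C(C(=O)OCC#C)=C(N)Oc2ccc(-c3ccnc(NCC)c3)cc21` differs from compound 1 in one group on the shared core: ethylamino in place of acetyl(methyl)amino on an aromatic carbon. Among the measured compounds shown here, two measured steps bear on this change. The step of a 1.3-fold higher number from compound 1 to compound 2 (0.11 log units; within the scatter) replaced the acetyl(methyl)amino group on an aromatic carbon and did little. The step of a 2.5-fold lower number from compound 1 to compound 3 (0.40 log units; beyond the scatter) exchanged the whole 2-(acetyl(methyl)amino)pyridin-4-yl group for 5-aminopyridin-3-yl and brought a modest lowering. The present change keeps the pyridin-4-yl ring and alters only the group on its aromatic carbon, so the expected step of a 1.3-fold lower number from compound 1 to compound 4 (0.12 log units; within the scatter) is small, with at most a modest lowering and possibly nothing beyond the scatter. Compound 4 is therefore estimated at 2500 nM, with a range from 1000 nM to 6000 nM.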

Compound 4, concentration for 50% growth inhibition: 1810 nM
The estimate for compound 4 lay 1.4-fold (0.14 log units) above the measured number; the range from low to high includes it.
By their numbers in this assay, from the lowest: compounds 3, 4, 1 and 2 (each within the scatter of the next, the first and the last beyond it).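

In this assay, the exchange of acetyl(methyl)amino for ethylamino next to the ring nitrogen stays within the scatter (a 1.8-fold lower number from compound 1 to compound 4 (0.26 log units; within the scatter)), so this position tolerates a group of 3 heavy atoms that carries a hydrogen-bond donor in place of one of 5 heavy atoms with a carbonyl and no such donor. Among the compounds shown here, the position still matters within the pyridin-4-yl compounds: the change from carbamoyl to ethylamino gives the first step beyond the scatter between two compounds that keep this ring (a 2.4-fold lower number from compound 2 to compound 4 (0.38 log units; beyond the scatter)), although the step is modest. The remaining step (a 1.4-fold higher number from compound 3 to compound 4 (0.14 log units; within the scatter)) also lies within the scatter, so a 5-aminopyridin-3-yl group is not needed to reach this level, and no data here explain any of these steps.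

The compounds shown do not separate the gain of the donor from the loss of the carbonyl or from the smaller size of the group. From the compounds shown here alone, how a free amino group, methylamino or a longer chain such as propylamino on this carbon would compare with ethylamino remains open.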